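Ester-to-acid step in a prenylated flavonol series: cytotoxicity outlook

This account rests on a few compounds, and the source may have more. Where it says the series, first, only, none or still open, it means among the compounds named here.

Among the compounds with values here, compound 3 `CCOC(=O)COc1cc(O)c2c(=O)c(O)c(-c3ccc(OC)cc3)oc2c1CC=C(C)C` is the one member of this set with a number in hand. In an ADME assay on Vero cells (Chlorocebus sabaeus) for cytotoxicity, read by MTT assay (a higher number here means a weaker inhibitor, a lower number a stronger inhibitor), compound 3 gives 1400 nM. Compound 1 `COc1ccc(-c2oc3c(CC=C(C)C)c(OCCOC(=O)CCC(=O)O)cc(O)c3c(=O)c2OCCOC(=O)CCC(=O)O)cc1` and compound 2 `COc1ccc(-c2oc3c(CC=C(C)C)c(OC(C(=O)O)C(=O)O)cc(O)c3c(=O)c2OC(C(=O)O)C(=O)O)cc1` carry related side chains on the shared core, but neither has a number: in this assay compound 1 gives "not determined" (no result reported), and in this assay compound 2 gives "not determined" (no result reported). Within the data shown here, compound 3 therefore stands alone, and no step between measured compounds can be read off.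

Compound 4 `COc1ccc(-c2oc3c(CC=C(C)C)c(OC(C)C(=O)O)cc(O)c3c(=O)c2O)cc1` differs from compound 3 in one place: 1-carboxyethyl in place of (ethoxycarbonyl)methyl on an oxygen on an aromatic ring. The (ethoxycarbonyl)methyl group leaves and a 1-carboxyethyl group enters, on an oxygen on an aromatic ring whose other neighbours are aromatic carbon; cut one bond further out, the change reads (ethoxycarbonyl)methoxy to 1-carboxyethoxy. Among the measured compounds shown here, with no pair of measured compounds to calibrate such a change, the expected step for compound 4 is taken as small, toward a weaker inhibitor in this assay, and it may well stay within the scatter; the step from compound 3 that this estimate means is a 1.8-fold higher number from compound 3 to compound 4 (0.25 log units; within the scatter). For compound 4 the expected value in this assay is 2500 nM, with a range from 800 nM to 8000 nM, and a fair chance that only a limit is reported.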

Compound 4, half-maximal inhibitory concentration: 19300 nM
Estimate against measurement, compound 4: 7.7-fold (0.89 log units) below; measured number outside the range, above it.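

Swapping (ethoxycarbonyl)methyl for 1-carboxyethyl on an oxygen on an aromatic ring gives a step of readable size in this assay: a 14-fold higher number from compound 3 to compound 4 (1.14 log units; beyond the scatter). This position therefore matters in this read-out, and the change moves the number toward a weaker inhibitor by a margin beyond the scatter, which compound 3 alone could not show. Nothing at hand explains the size of this step.

The step combines two differences, since the ethyl ester gives way to a carboxylic acid and the chain also carries a methyl branch, and the compounds shown do not separate them: a carboxymethyl group or a 1-(ethoxycarbonyl)ethyl group on the same oxygen would be needed to assign the step to one or the other. Steps involving compound 1 and compound 2 cannot be read, so it also remains open how the side chains on the second oxygen of those two compounds, or a longer chain ending in a carboxylic acid, would behave in this assay.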